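The source may report more compounds than this note shows. Statements on the series, on what has been measured and on what is new or still open speak of the compounds shown alone.

Measured so far in a functional assay on A549 cells (Homo sapiens) for inhibition, read by sulforhodamine B assay, with a stated time of 48 h, tested at 10 uM; a higher number here means a weaker effect of the compound at the concentration tested, a lower number a stronger effect:
compound 1, `O=C(Nc1cccc(-n2cc(-c3ccncc3)c(-c3cc(O)cc(Cl)c3)n2)c1)Nc1ccc(Cl)c(C(F)(F)F)c1`, gives 8.81%
compound 2, `COc1cc(Cl)cc(-c2nn(-c3cccc(NC(=O)Nc4ccc(Cl)c(C(F)(F)F)c4)c3)cc2-c2ccncc2)c1`, gives 5.2%
compound 3, `COc1cc(Cl)cc(-c2nn(-c3cccc(NC(=O)Nc4cc(C(F)(F)F)cc(C(F)(F)F)c4)c3)cc2-c2ccncc2)c1`, gives 5.14%

Among these three numbers, compound 2 stands second highest. For the measured compounds named here, its value and that of compound 3 lie within the scatter of each other, and the single measured step, a number 3.6 percentage points lower from compound 1 to compound 2 (within the scatter), is also within the scatter, so the three compounds cannot be told apart in this assay.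

Compound 4, `COc1cc(Cl)cc(-c2nn(-c3cccc(NC(=O)c4cccc(C(F)(F)F)c4)c3)cc2-c2ccncc2)c1`, differs from compound 2 at the carbonyl carbon: 3-(trifluoromethyl)phenyl in place of (4-chloro-3-(trifluoromethyl)phenyl)amino on a carbonyl carbon. Going by the values given here, no measured step touches this part of the molecule. Among the compounds with values here, the only step on record, methyl in place of hydrogen on an oxygen on an aromatic ring, bears on a different position and was within the scatter, so it gives no guide to the size or direction of the present change. Compound 4 is therefore estimated to give 15%, with a range from 3% to 45%. The step of a number 9.8 percentage points higher from compound 2 to compound 4 (within the scatter) is expected to be modest, but the range is kept wide because nothing measured bears on it.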

Compound 4, a percentage reported as activity, at one concentration (the size of the read-out at that concentration, not a potency): 39.1%
Estimate against measurement, compound 4: 24.1 percentage points below, and the stated range covers the measured number.
By their numbers in this assay, from the lowest: compounds 3, 2 and 1 (each within the scatter of the next); then compound 4.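

In this assay, the position on the carbonyl carbon responds where the oxygen on the aromatic ring of compound 1 did not: replacing (4-chloro-3-(trifluoromethyl)phenyl)amino with 3-(trifluoromethyl)phenyl gives the only step shown that lies beyond the scatter (a number 33.9 percentage points higher from compound 2 to compound 4 (beyond the scatter)), and it means a weaker effect at the concentration tested. This single change removes the amino nitrogen with its hydrogen-bond donor and also the chlorine, so the step shows only that the two losses together matter, not which one does. Nothing at hand explains the step.

The compounds shown leave the two losses unseparated, and the pair that would divide them is (3-(trifluoromethyl)phenyl)amino and 4-chloro-3-(trifluoromethyl)phenyl on the same carbonyl carbon. As far as these compounds go, how other groups at this place, such as an alkylamine or a longer carbon chain, would read also stays open.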